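Shortening the ring-nitrogen chain from butyl to methyl

The compounds below may be only part of what the source reports. "The series", "measured", "known", "first", "only" and "open" are said of these compounds alone.

Of the compounds shown here, three sharing one core have been tested in a functional assay on the whole organism (strain Kunming) with Mus musculus as the target, with a stated time of 4 h; a higher number here means that more compound is needed for the effect, a lower number that less compound is needed. Compound 1 `O=C1NC2(CC2c2ccc3cccc(OCc4ccccc4)c3n2)C(=O)N1c1ccc(C(F)(F)F)cc1` gives 300 mg/kg. Compound 2 `CCC(CO)N1C(=O)NC2(CC2c2ccc3cccc(OCc4ccccc4)c3n2)C1=O` gives 300 mg/kg, and compound 3 `CCCCN1C(=O)NC2(CC2c2ccc3cccc(OCc4ccccc4)c3n2)C1=O` gives 300 mg/kg. Compound 3 therefore stands level with its two neighbours: no change at the digits printed from compound 1 to compound 3 (within the scatter) and no change at the digits printed from compound 2 to compound 3 (within the scatter), and likewise no change at the digits printed from compound 1 to compound 2 (within the scatter).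

Compound 4 `CN1C(=O)NC2(CC2c2ccc3cccc(OCc4ccccc4)c3n2)C1=O` has not yet been measured. Its difference from compound 3 is counted as hydrogen in place of propyl on a saturated chain carbon bound to an amide-type nitrogen in a ring, which, read one bond further out, is butyl to methyl. The measured steps all change the group on the amide-type nitrogen in the ring, from an aryl group to a branched hydroxyalkyl chain to butyl, and none of them moved the minimum effective dose beyond the scatter. Going by the values given here, no measured step shortens the chain itself, so the bearing of those steps is indirect, but they give no ground to expect a shift in either direction. Compound 4 is thus expected to lie at 300 mg/kg, within 100 mg/kg to 600 mg/kg, and the step is estimated as no change at the digits printed from compound 3 to compound 4 (within the scatter).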

Compound 4, minimum effective dose: 300 mg/kg
Estimate against measurement, compound 4: no gap at the digits printed; the measured number falls inside the stated range.
By their numbers in this assay, from the lowest: compounds 1, 2, 3 and 4 (each within the scatter of the next).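

This is the only step shown that shortens the chain itself on the amide-type nitrogen in the ring, and in this assay it gives no change at the digits printed from compound 3 to compound 4 (within the scatter), so cutting butyl to methyl leaves the minimum effective dose where it was. Methyl also matches the other two groups, with no change at the digits printed from compound 2 to compound 4 (within the scatter) and no change at the digits printed from compound 1 to compound 4 (within the scatter), so this position now reads alike with an aryl group, a branched hydroxyalkyl chain, a straight butyl chain and methyl. No evidence is available that accounts for this result.

On these data alone, with all four compounds at one reading, it remains open whether any group at this position can shift the minimum effective dose. A chain bearing an amine or a carboxylic acid, a bare hydrogen on that nitrogen, and changes elsewhere on the shared core are all still untested here.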